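Sulfonamide-bearing triazole analogue in a weak antiproliferative series

A few compounds are considered here, and "the series" means these few. Any claim that something is new, unique, unknown or untested is made for them only; others in the source may bear on it.

Compound 3 `O=C1O[C@H]([C@@H](O)Cn2cc(CCCCl)nn2)C(OCc2ccccc2)=C1OCc1ccccc1` gives 58800 nM in a functional assay on CFPAC-1 cells (Homo sapiens) for antiproliferative activity, read by MTT assay, with a stated time of 72 h (on this read-out lower numbers stand for stronger inhibition and higher numbers for weaker inhibition), the highest of the three numbers measured. Compound 1 `O=C1O[C@H]([C@@H](O)Cn2cc(-c3cccc(O)c3)nn2)C(OCc2ccccc2)=C1OCc1ccccc1` gives 54100 nM in this assay; the step is a 1.1-fold higher number from compound 1 to compound 3 (0.04 log units; within the scatter). Compound 2 `CCCCCc1ccc(-c2cn(C[C@H](O)[C@H]3OC(=O)C(OCc4ccccc4)=C3OCc3ccccc3)nn2)cc1` gives 9890 nM in this assay; the step is a 5.9-fold higher number from compound 2 to compound 3 (0.77 log units; beyond the scatter). Compound 4 `Cc1ccc(S(=O)(=O)NCc2cn(C[C@H](O)[C@H]3OC(=O)C(OCc4ccccc4)=C3OCc3ccccc3)nn2)cc1` differs from compound 3 by ((4-methylphenyl)sulfonyl)amino in place of 2-chloroethyl on a saturated chain carbon bound to an aromatic carbon. For the measured compounds named here, two measured steps bear on this change: a 1.1-fold higher number from compound 1 to compound 3 (0.04 log units; within the scatter), within the scatter, and a 5.9-fold higher number from compound 2 to compound 3 (0.77 log units; beyond the scatter), beyond it. An aromatic ring in this position thus either lowers the number, as compound 2 shows, or leaves it unchanged, as compound 1 shows. Compound 4 carries an aromatic ring together with one hydrogen-bond donor, so a modest lowering is expected, a 2.0-fold lower number from compound 3 to compound 4 (0.29 log units; within the scatter). Compound 4 is therefore estimated at 30000 nM, with a range from 10000 nM to 90000 nM.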

Compound 4, half-maximal inhibitory concentration: 68000 nM
Compound 4: the middle estimate sits 2.3-fold (0.36 log units) below what was measured; low and high end bracket the measured number.
By their numbers in this assay, from the lowest: compound 2; then compounds 1, 3 and 4 (each within the scatter of the next).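

In this assay, placing the ((4-methylphenyl)sulfonyl)amino group on the chain gives no change beyond the scatter, with a 1.2-fold higher number from compound 3 to compound 4 (0.06 log units; within the scatter). For the compounds shown here, an aromatic ring carried on this chain therefore does not by itself lower the number, a point the earlier compounds left undecided. The other steps read a 1.3-fold higher number from compound 1 to compound 4 (0.10 log units; within the scatter) and a 6.9-fold higher number from compound 2 to compound 4 (0.84 log units; beyond the scatter), so among these four only the 4-pentylphenyl group stands apart.

No evidence here explains this result. Still open, as far as these compounds go, is whether that lower number follows the pentyl chain or the phenyl ring, and how an unsubstituted phenyl, an octyl chain or an amine would read here.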